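This account rests on a few compounds, and the source may have more. Where it says the series, first, only, none or still open, it means among the compounds named here.

Compound 1 (`CCOC(=O)CN1CCN(c2c(F)cc3c(=O)c(C(=O)O)cn(C4CC4)c3c2OC)CC1C`), compound 2 (`CCOC(=O)CCN1CCN(c2c(F)cc3c(=O)c(C(=O)O)cn(C4CC4)c3c2OC)CC1C`) and compound 3 (`COc1c(N2CCN(C/C(C)=N/NC(N)=O)C(C)C2)c(F)cc2c(=O)c(C(=O)O)cn(C3CC3)c12`) share one core. In an ADME assay on Vero cells (Chlorocebus sabaeus) for cytotoxicity, read by MTT assay, with a stated time of 72 h (a lower number here means that less compound is tolerated, a higher number that more compound is tolerated), compound 3 gives 500 ug/mL, which lies within the scatter of compound 1 at 1000 ug/mL. In this assay compound 2 has the entry "not determined" (no result reported). Compound 4 (`CCO/N=C(\C)CCN1CCN(c2c(F)cc3c(=O)c(C(=O)O)cn(C4CC4)c3c2OC)CC1C`) differs from compound 3 as follows: a group of 7 heavy atoms (5 carbon, 1 nitrogen, 1 oxygen; no ring) in place of a group of 7 heavy atoms (3 carbon, 3 nitrogen, 1 oxygen; no ring), on a saturated chain carbon bound to an amine nitrogen in a ring. The change sits on a saturated chain carbon bound to an amine nitrogen in a ring. Among the measured compounds shown here, the only measured step at that place is a 2.0-fold lower number from compound 1 to compound 3 (0.30 log units; within the scatter), and it involves a different incoming group, so it offers weak guidance. With that single step inside the scatter, none beyond the scatter is expected here, and the estimated step is no change at the digits printed from compound 3 to compound 4 (within the scatter). For compound 4 the estimated value is 500 ug/mL, with an expected range from 220 ug/mL to 1000 ug/mL.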

Compound 4, half-maximal cytotoxic concentration: 88.4 ug/mL
Beside the measured number, compound 4's estimate is 5.7-fold (0.75 log units) above it, outside the stated range (below it).
By their numbers in this assay, from the lowest: compound 4; then compounds 3 and 1 (each within the scatter of the next).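

In this assay, among the compounds shown here, this place on a saturated chain carbon bound to an amine nitrogen in a ring now shows a change beyond the scatter, which the only earlier step did not: a 5.7-fold lower number from compound 3 to compound 4 (0.75 log units; beyond the scatter). Measured against the ester of compound 1, the change is larger: an 11-fold lower number from compound 1 to compound 4 (1.05 log units; beyond the scatter). No measurement here accounts for either step.

As far as these compounds go, whether the lower number follows from the group that enters in compound 4 as a whole or from one part of it remains open. So does how a simple amine or a carboxylic acid at this place would compare.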